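The source may report more compounds than this note shows. Statements on the series, on what has been measured and on what is new or still open speak of the compounds shown alone.

In an assay on membranes from brain for displacement of a labelled ligand from Sigma non-opioid intracellular receptor 1 (Cavia porcellus), read by radioligand binding (a higher number here means a weaker inhibitor, a lower number a stronger inhibitor), compound 1 `CCN(CCCCc1cn(-c2ccc(F)cc2)c2ccccc12)[C@H]1CCc2c1ccc(OC)c2OC` gives 50.8 nM. Compound 2 `CCN(CCCCc1cn(-c2ccc(F)cc2)c2ccccc12)[C@@H]1CCc2c1ccc(OC)c2OC` gives 126 nM, and the modest step of a 2.5-fold higher number from compound 1 to compound 2 (0.39 log units; beyond the scatter) rests on the fact that (the fact that compounds 1 and 2 differ only in the configuration as drawn). Compound 3 `COc1ccc2c(c1OC)CC[C@@H]2NCCCCc1cn(-c2ccc(F)cc2)c2ccccc12` carries hydrogen in place of ethyl on the amine nitrogen and gives 122 nM, a change described by a 2.4-fold higher number from compound 1 to compound 3 (0.38 log units; beyond the scatter). Among the three numbers compound 3 stands second highest: its number sits within the scatter of compound 2, while it lies clearly apart from compound 1.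

The next compound, compound 4 `COc1ccc2c(c1OC)CC[C@H]2NCCCCc1cn(-c2ccc(F)cc2)c2ccccc12`, differs from compound 3 in one way: the two compounds have the same atoms and bonds and differ only in configuration as drawn: 1 of 1 stereo elements differ; a stereocentre at a saturated ring carbon is drawn S in compound 3 and R in compound 4. Going by the values given here, the only measured step that bears on this change is a 2.5-fold higher number from compound 1 to compound 2 (0.39 log units; beyond the scatter), where the same switch of configuration at the saturated ring carbon, in the pair bearing ethyl on the nitrogen, gave a modestly weaker inhibitor. A step of similar size and in the same direction is therefore expected in this assay; the expected step is a 2.5-fold higher number from compound 3 to compound 4 (0.39 log units; beyond the scatter). Compound 4 is thus estimated to give about 300 nM, with a likely range from 150 nM to 600 nM.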

Compound 4, inhibition constant: 175 nM
Estimate against measurement, compound 4: 1.7-fold (0.23 log units) above; measured number inside the range.
By their numbers in this assay, from the lowest: compound 1; then compounds 3, 2 and 4 (each within the scatter of the next).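

In this assay, with hydrogen on the amine nitrogen, the switch from S to R at the saturated ring carbon gives a 1.4-fold higher number from compound 3 to compound 4 (0.16 log units; within the scatter), so this pair shows no clear effect of configuration, unlike the pair bearing ethyl, which gave a 2.5-fold higher number from compound 1 to compound 2 (0.39 log units; beyond the scatter). Hydrogen in place of ethyl on the amine nitrogen, now read with the stereocentre drawn R, gives a 1.4-fold higher number from compound 2 to compound 4 (0.14 log units; within the scatter), but this does not establish that the change acts differently on the two forms: the same change on two cores in this assay, a 2.4-fold higher number (0.38 log units; beyond the scatter) from compound 1 to compound 3 and a 1.4-fold higher number (0.14 log units; within the scatter) from compound 2 to compound 4, 1.7-fold (0.24 log units) apart, within the scatter of two such steps. A clear difference between the two configurations therefore appears only in the ethyl pair and does not extend to the hydrogen pair.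

The compounds shown leave open whether a propyl or benzyl group on the amine nitrogen would bring out a clear difference between the two configurations. They also leave open whether a longer chain would do the same.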